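The compounds below may be only part of what the source reports. "The series", "measured", "known", "first", "only" and "open" are said of these compounds alone.

Working notes on the indole series.

The shared core is common to compound 1 `CC(=O)/C(=C/c1c(-c2ccccc2)[nH]c2ccccc12)C(=O)c1ccccc1`, compound 2 `CCOC(=O)/C(=C/c1c(-c2ccccc2)[nH]c2ccccc12)C(=O)c1ccc([N+](=O)[O-])cc1` and the not yet tested compound 3 `CCOC(=O)/C(=C/c1c(-c2ccccc2)[nH]c2ccccc12)C(=O)c1ccccc1`. Among the compounds with values here, in a functional assay on MCF7 cells (Homo sapiens) for cytotoxicity, read by MTT assay, with a stated time of 96 h (on this read-out lower numbers stand for an effect already at smaller amounts and higher numbers for an effect only at larger amounts of compound), compound 2 gives 40000 nM, the only number so far in this read-out. For compound 1 the assay returns only a limit, > 100000 nM, not a number; this is the point at which (the limit of > 100000 nM in this assay, at which 1 of the 2 values shown sits). Within the data shown here, compound 2 therefore stands alone as the one measured compound, and the pair compound 1 to compound 2 differs in more than one place, so it yields no single step to lean on.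

The move from compound 2 to compound 3 is hydrogen in place of nitro on an aromatic carbon, cut further out a (4-nitrophenyl)carbonyl becoming a benzoyl. Among the measured compounds shown here, no measured step between two compounds in this assay is available, so the size of this step cannot be read off. Compound 1, which also carries the phenyl but differs elsewhere too, shows only the limit.

The estimate for compound 3 in this assay is 80000 nM, with a range from 30000 nM to 250000 nM. This expected value corresponds to a step of a 2.0-fold higher number from compound 2 to compound 3 (0.30 log units; within the scatter), toward higher numbers, and a real chance that compound 3 also reaches only the limit is expected.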

Compound 3, half-maximal effective concentration: 43000 nM
Estimate against measurement, compound 3: 1.9-fold (0.27 log units) above, and the stated range covers the measured number.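

Working notes, continued. In this assay, hydrogen in place of nitro on an aromatic carbon, para to a large group, gives a 1.1-fold higher number from compound 2 to compound 3 (0.03 log units; within the scatter), so compound 2 and compound 3 cannot be told apart and the nitro shows no measurable contribution at this position. Within the data shown here, the other change, ethoxy in place of methyl on a carbonyl carbon, gives an at least 2.3-fold lower number from compound 1 to compound 3 (0.36 log units; beyond the scatter), so the one step beyond the scatter comes from that carbonyl substituent and not from the aromatic ring. The full size of that step stays unknown, since compound 1 gives > 100000 nM in this assay, which is a limit and not a number: the limit of > 100000 nM in this assay, at which 1 of the 3 values shown sits.

The compounds shown leave open whether an amine or a carboxylic acid on the same aromatic carbon would separate from compound 3, given that nitro and hydrogen do not separate. Also open, as far as these compounds go, is whether a longer chain than ethoxy on the carbonyl carbon, such as butoxy, would carry the number further in the direction seen from methyl to ethoxy.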